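This account rests on a few compounds, and the source may have more. Where it says the series, first, only, none or still open, it means among the compounds named here.

Measured so far:
- compound 1, `CC(C)[C@@H]1CC[C@@H](C)C[C@@]12N(C)C(=O)[C@@H]1[C@H]3C(=O)N(c4ccccc4)C(=O)[C@H]3ON12`: 21.6%
- compound 2, `Cc1cccc(N2C(=O)[C@H]3[C@H](ON4[C@@H]3C(=O)N(C)[C@@]43C[C@H](C)CC[C@H]3C(C)C)C2=O)c1`: 26.8%

In a functional assay, with a stated time of 20 min, tested at 0.5 mg/mL (on this read-out lower numbers stand for a weaker effect and higher numbers for a stronger effect at the one concentration tested), compound 1 gives 21.6%, and compound 2 gives 26.8%. Among the compounds with values here, of these two numbers, the one for compound 2 is the higher, but the step of a number 5.2 percentage points higher from compound 1 to compound 2 (within the scatter) stays within the scatter, so the two compounds read as alike rather than ordered. That step is the only one measured, and it touched the same aromatic ring that changes now.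

Compound 3, `CC(C)[C@@H]1CC[C@@H](C)C[C@@]12N(C)C(=O)[C@@H]1[C@H]3C(=O)N(c4ccc5ccccc5c4)C(=O)[C@H]3ON12`, differs from compound 2 in one place: naphthalen-2-yl in place of 3-methylphenyl on an amide-type nitrogen in a ring. Within the data shown here, the single step seen, a number 5.2 percentage points higher from compound 1 to compound 2 (within the scatter), gives no hint of a shift beyond the scatter when this ring is altered, and nothing measured speaks to a second fused aromatic ring. The step from compound 2 to compound 3 is therefore expected to stay within the scatter, as a number 3.2 percentage points higher from compound 2 to compound 3 (within the scatter). Compound 3 is estimated at 30%, between 12% and 48%.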

Compound 3, a percentage reported as activity, at one concentration (the size of the read-out at that concentration, not a potency): 13.8%
Compound 3: the middle estimate sits 16.2 percentage points above what was measured, within the range that was stated.
By their numbers in this assay, from the lowest: compounds 3, 1 and 2 (each within the scatter of the next, the first and the last beyond it).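

In this assay, within the data shown here, the group on the amide-type nitrogen can move the read-out beyond the scatter: naphthalen-2-yl in place of 3-methylphenyl gives a number 13 percentage points lower from compound 2 to compound 3 (beyond the scatter) and is the first step of modest size in this short series. Set against the plain phenyl group, the same naphthalen-2-yl gives a number 7.8 percentage points lower from compound 1 to compound 3 (within the scatter) so the second fused aromatic ring separates compound 3 from compound 2 only, while compound 1 and compound 3 read as alike. Nothing available explains the drop seen with compound 3.

As far as these compounds go, whether a cyclohexyl group, a benzyl group, or a phenyl group carrying an amine or a carboxylic acid would hold, raise or lower the read-out at this position stays open. All three compounds share the rest of the core, so how these aromatic groups behave on a different core is also unknown.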